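A few compounds are considered here, and "the series" means these few. Any claim that something is new, unique, unknown or untested is made for them only; others in the source may bear on it.

Three amides sharing one core have been tested in an ADME assay on BaF3 cells (Mus musculus) for antiproliferative activity; on this read-out lower numbers stand for stronger inhibition of growth and higher numbers for weaker inhibition of growth. Compound 1 `Cc1ccc(NC(=O)c2ccc(C)c(C(F)(F)F)c2)cc1OC1CCN(C(=O)c2cccnc2)CC1` gives 5470 nM in this assay. Compound 2 `Cc1ccc(NC(=O)c2cc(Cl)cc(C(F)(F)F)c2)cc1OC1CCN(C(=O)c2cccnc2)CC1` reaches only the limit of this assay, reported as > 10000 nM. Compound 3 `Cc1ccc(NC(=O)c2cc(C(C)(C)C)on2)cc1OC1CCN(C(=O)c2cccnc2)CC1` likewise reaches only the limit, reported as > 10000 nM, which is a limit and not a number (the limit of > 10000 nM in this assay, at which 2 of the 3 values shown sit). The measured steps are an at least 1.8-fold higher number from compound 1 to compound 2 (0.26 log units; that floor lies within the scatter) and an at least 1.8-fold higher number from compound 1 to compound 3 (0.26 log units; that floor lies within the scatter), while the step that the two limits leave unreadable from compound 2 to compound 3. Compound 4 `Cc1ccc(NC(=O)c2cnc3ccccc3c2)cc1OC1CCN(C(=O)c2cccnc2)CC1` differs from compound 3 in one place: quinolin-3-yl in place of 5-(tert-butyl)-1,2-oxazol-3-yl on a carbonyl carbon. For the measured compounds named here, none of the measured steps involves a bicyclic aryl group of this kind, and two of the three values shown are limits, so the direction of the change in this assay cannot be read from them. A cautious expectation is that compound 4 returns into the numeric range of this assay, with a step estimated as an at least 1.2-fold lower number from compound 3 to compound 4 (0.09 log units; that floor lies within the scatter). Compound 4 is therefore estimated at 8000 nM, with a range from 2000 nM to 30000 nM.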

Compound 4, concentration for 50% growth inhibition: > 10000 nM
Compound 4: only a limit was reported; the forecaster's own chance of this, stated with the estimate: 45%; at least 1.2-fold (0.09 log units) between middle value and limit.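

In this assay compound 4 gives > 10000 nM, which is a limit and not a number. With quinolin-3-yl on this carbonyl carbon, the only bicyclic aryl group shown, the step is an at least 1.8-fold higher number from compound 1 to compound 4 (0.26 log units; that floor lies within the scatter), so a fused ring system does not bring the read-out back into the numeric range here. The steps from compound 2 and from compound 3 to compound 4 cannot be read, which leaves these three groups unordered, and the series now stands as follows: the limit of > 10000 nM in this assay, at which 3 of the 4 values shown sit.

Going by these compounds, whether any group on this carbonyl carbon gives a lower number than compound 1, at 5470 nM, remains open. Also open, on these data alone, is how a phenyl group carrying an amine or a carboxylic acid would read there in this assay.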